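A few compounds are considered here, and "the series" means these few. Any claim that something is new, unique, unknown or untested is made for them only; others in the source may bear on it.

Of the compounds shown here, three have so far been read in a functional assay on PC-3 cells (Homo sapiens) for antiproliferative activity, read by MTT assay, with a stated time of 48 h; on this read-out higher numbers stand for weaker inhibition and lower numbers for stronger inhibition. In it, compound 1 `O=C(/C=C/c1ccc(/C=C/C(=O)c2ccc3ccccc3c2)o1)NO` gives 15100 nM, compound 2 `COc1cc(/C=C/c2ccc(C(=O)NO)o2)ccc1OCc1ccccc1` gives 1200 nM and compound 3 `O=C(/C=C/c1ccc(/C=C/C(=O)c2cccc(Cl)c2)o1)NO` gives 9600 nM. Compound 3 therefore stands within the scatter of compound 1, while its number is higher than that of compound 2 by a margin beyond the scatter.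

Compound 4 `O=C(/C=C/c1ccc(/C=C/C(=O)c2ccccc2)o1)NO` takes compound 3 as its starting point, with hydrogen in place of chloro on an aromatic carbon, so that 3-chlorophenyl becomes phenyl: hydrogen in place of chloro on an aromatic carbon. For the measured compounds named here, no measured pair isolates this change. The nearest guide is compound 1, which carries another ring group in place of the 3-chlorophenyl and gives 15100 nM, within the scatter of compound 3. No shift beyond the scatter is therefore expected in this assay, in either direction. The expected step, a 1.0-fold higher number from compound 3 to compound 4 (0.02 log units; within the scatter), is estimated to stay within the scatter. Compound 4 is estimated at 10000 nM, with an expected range of 4500 nM to 22000 nM.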

Compound 4, half-maximal inhibitory concentration: 13300 nM
For compound 4 the middle estimate is 1.3-fold (0.12 log units) below the measured one; low and high end bracket the measured number.
By their numbers in this assay, from the lowest: compound 2; then compounds 3, 4 and 1 (each within the scatter of the next).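

For the compounds shown here, this pair isolates the change at this position for the first time: in this assay, replacing chloro with hydrogen on the aromatic carbon gives a 1.4-fold higher number from compound 3 to compound 4 (0.14 log units; within the scatter). Within this assay's scatter, then, the 3-chlorophenyl and phenyl forms of this core cannot be told apart, and the chlorine is not required for a measurable antiproliferative read-out in the micromolar range. What lies behind this result cannot be said, as no supporting evidence bears on it.

Going by these compounds, it remains open whether a group of another kind at this place, such as an amine, a methoxy group or a carboxylic acid, would move the number beyond the scatter. On these data alone, it is also open whether chloro on another carbon of the ring would behave as it does here.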